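The source may report more compounds than this note shows. Statements on the series, on what has been measured and on what is new or still open speak of the compounds shown alone.

Among the compounds with values here, compound 1 `COc1cccc(OC)c1C(=O)Nc1c[nH]nc1C(=O)NCC1CCCCC1` is one of two compounds measured so far in an ADME assay on MRC5 cells (Homo sapiens) for inhibition, with a stated time of 72 h; on this read-out higher numbers stand for an effect only at larger amounts of compound and lower numbers for an effect already at smaller amounts. In this assay compound 1 gives > 50000 nM, which is a limit of the assay and not a number; compound 1 therefore sits at the limit of > 50000 nM in this assay, at which 1 of the 2 values shown sits. The second measured compound, compound 2 `CO[C@H]1CC[C@H](NC(=O)c2n[nH]cc2NC(=O)c2ccccc2F)CC1`, in this assay gives 1000 nM. Within the data shown here, no pair of the measured compounds differs in one place only, so no measured step is available.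

Compound 3 `COc1cccc(OC)c1C(=O)Nc1c[nH]nc1C(=O)NC1CCCCC1` has not yet been measured in this assay. It differs from compound 1 by cyclohexyl in place of cyclohexylmethyl on an amide-type nitrogen. Compound 1 gives > 50000 nM as a limit, and a change of this small size is expected to stay within the scatter, so the step of a number no higher from compound 1 to compound 3 (the limit leaves the size open) is estimated to be none beyond the scatter. Compound 3 is therefore expected to give about 50000 nM in this assay, within a range from 20000 nM to 120000 nM, most likely again as a limit.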

Compound 3, half-maximal effective concentration: 35000 nM
Estimate against measurement, compound 3: 1.4-fold (0.15 log units) above, and the stated range covers the measured number.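

Cyclohexyl in place of cyclohexylmethyl on the amide-type nitrogen gives the first measured change at this position, and in this assay compound 3 gives a number, 35000 nM, and not a limit. The change amounts to an at least 1.4-fold lower number from compound 1 to compound 3 (0.15 log units; that floor lies within the scatter). Its full size cannot be read because compound 1 stands at a limit of the assay and not at a number: the limit of > 50000 nM in this assay, at which 1 of the 3 values shown sits.

The compounds shown leave open how a longer chain, such as cyclohexylethyl, or a cyclohexyl ring carrying an amine or a carboxylic acid, would read on this nitrogen. They also leave open whether the same change would give a similar step with a different group on the other amide of the shared core.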